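Nitro in Place of Chloro: What to Expect for Compound 4

The source may report more compounds than this note shows. Statements on the series, on what has been measured and on what is new or still open speak of the compounds shown alone.

In a functional assay on the whole organism (strain albino) for inhibition, with Mus musculus as the target, with stated times of 30 min and 5 min, at a dose of 60 mg/kg by the intraperitoneal route (a higher number here means more inhibition at the dose given (going by the name of the read-out), a lower number less inhibition), the three measured compounds gave:
compound 1 `CCN(CC)CCCOc1ccc2sc(=O)oc2c1`: 53.3%
compound 2 `O=c1oc2cc(OCCCN3CCNCC3)ccc2s1`: 62.3%
compound 3 `O=c1oc2cc(OCCCOc3ccc(Cl)cc3)ccc2s1`: 49.3%

Compound 3 stands lowest of the three; compound 1 lies within the usual scatter of it, while compound 2 lies beyond it. Compound 4 `O=c1oc2cc(OCCCOc3ccc([N+](=O)[O-])cc3)ccc2s1` differs from compound 3 by nitro in place of chloro on an aromatic carbon. Among the compounds with values here, the only measured step, a number 9 percentage points higher from compound 1 to compound 2 (within the scatter), swaps a group on a saturated chain carbon, not on an aromatic ring, so no measured step bears directly on this change, and that step was itself within the scatter. A change no larger than the scatter is therefore expected, a number 0.7 percentage points higher from compound 3 to compound 4 (within the scatter). Compound 4 is expected to give 50% in this assay, with a range of 35% to 65%.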

Compound 4, a percentage reported as inhibition, in the whole organism at one dose (the size of the read-out at that dose, not a potency): 67.3%
For compound 4 the middle estimate is 17.3 percentage points below the measured one; measured number outside the range, above it.
By their numbers in this assay, from the lowest: compounds 3, 1, 2 and 4 (each within the scatter of the next, the first and the last beyond it).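

In this assay, nitro in place of chloro on an aromatic carbon, para to a large group, gives a number 18 percentage points higher from compound 3 to compound 4 (beyond the scatter) and so shows that the number responds to what sits at this position. Within the data shown here, this is the first step measured on this ring, and the first between compounds differing in one place to lie beyond the scatter. No evidence is available on why the number changes here.

Going by these compounds, whether an amine or a carboxylic acid at this position would also raise the number remains open. So does whether nitro would give a similar step with a longer chain.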